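Two bromophenyl compounds and a fluorine swap

A few compounds are considered here, and "the series" means these few. Any claim that something is new, unique, unknown or untested is made for them only; others in the source may bear on it.

Compound 1 (`CC(=O)N1N=C(c2ccc3ccccc3c2)OC1c1cccc(Br)c1`): 2.36 ug/mL
Compound 2 (`CC(=O)N1N=C(c2ccc3ccccc3c2)OC1c1ccc(Br)cc1`): 4.68 ug/mL

Among the compounds with values here, in a functional assay on B16-F10 cells (Mus musculus) for antiproliferative activity, read by MTT assay, with a stated time of 48 h (a higher number here means a weaker inhibitor, a lower number a stronger inhibitor), compound 2 gives 4.68 ug/mL and stands level with compound 1, the only other measured compound. Compound 3 (`CC(=O)N1N=C(c2ccc3ccccc3c2)OC1c1cccc(F)c1`) keeps the shared core and the acetyl group but carries 3-fluorophenyl in place of 4-bromophenyl on a saturated ring carbon. Within the data shown here, one measured step bears on this: exchanging 3-bromophenyl for 4-bromophenyl gave a 2.0-fold higher number from compound 1 to compound 2 (0.30 log units; within the scatter) and that stays within the usual scatter. Among the measured compounds shown here, no measured pair shows fluorine taking the place of bromine, so that part of the change remains unknown. A step beyond the scatter is therefore not expected in this assay although the untested fluorine leaves room on either side. The estimated move is a 1.4-fold lower number from compound 2 to compound 3 (0.15 log units; within the scatter) and it is expected to remain small. The expected value for compound 3 is 3.3 ug/mL within an estimated range of 1.3 ug/mL to 8 ug/mL for a single measurement.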

Compound 3, half-maximal inhibitory concentration: 1.61 ug/mL
Beside the measured number, compound 3's estimate is 2.0-fold (0.31 log units) above it; measured number inside the range.
By their numbers in this assay, from the lowest: compounds 3, 1 and 2 (each within the scatter of the next, the first and the last beyond it).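

In this assay, within the data shown here, the swap of 4-bromophenyl for 3-fluorophenyl gives the first step in this short series to clear the scatter, a 2.9-fold lower number from compound 2 to compound 3 (0.46 log units; beyond the scatter), though it is only modest and changes both the halogen and its place on the phenyl ring. Fluoro in place of bromo with that place held fixed gives a 1.5-fold lower number from compound 1 to compound 3 (0.17 log units; within the scatter), which lies within the scatter, so this pair does not separate the two halogens at this ring carbon. Moving the bromine alone also stayed within the scatter, so only the change combining both differences stands out, and no measurement shown accounts for this.

As far as these compounds go, it remains open whether fluorine placed where compound 2 carries its bromine would stand closer to compound 2 or to compound 3, which would show whether the halogen's place matters apart from its identity. Also open, from the compounds shown here alone, is how this phenyl ring would respond to a group other than a halogen, such as a methoxy group or an amine, and how the series would respond to a longer chain in place of the acetyl group.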